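Methyl on the Ring Amide Nitrogen in a Fused Core

The source may report more compounds than this note shows. Statements on the series, on what has been measured and on what is new or still open speak of the compounds shown alone.

Measured so far:
compound 1 `CN1C/C(=C\c2ccccc2)C(=O)[C@]2(C1)[C@@H](c1ccccc1)CN(C)[C@@]21C(=O)Nc2ccccc21` gives 71.4%
compound 2 `CN1C/C(=C\c2ccccc2)C(=O)[C@]2(C1)[C@@H](c1ccccc1)CN(C)[C@@]21C(=O)N(C)c2ccccc21` gives 75.6%
compound 3 `CN1C/C(=C\c2ccc(-c3cccs3)cc2)C(=O)[C@]2(C1)[C@@H](c1ccc(-c3cccs3)cc1)CN(C)[C@@]21C(=O)Nc2ccccc21` gives 74.8%

All three were tested in a functional assay on the whole organism (strain Wister albino) for inhibition, with Rattus norvegicus as the target, read by paw edema, with stated times of 1 h and 3 h, at a dose of 50 mg/kg by the intraperitoneal route; on this read-out lower numbers stand for less inhibition and higher numbers for more inhibition at the one dose given (going by the name of the read-out). Compound 1 and compound 2 share a core and differ in one place: methyl in place of hydrogen on an amide-type nitrogen in a ring. That change gave a number 4.2 percentage points higher from compound 1 to compound 2 (within the scatter). Compound 3 carries a different core, and the difference between the two cores is not broken down here. Compound 3 and compound 2 lie within the scatter of each other, as do compound 3 and compound 1.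

Compound 4 `CN1C/C(=C\c2ccc(-c3cccs3)cc2)C(=O)[C@]2(C1)[C@@H](c1ccc(-c3cccs3)cc1)CN(C)[C@@]21C(=O)N(C)c2ccccc21` is not yet measured. It differs from compound 3 by methyl in place of hydrogen on an amide-type nitrogen in a ring, the same change already seen between compound 1 and compound 2. Because that earlier change gave a number 4.2 percentage points higher from compound 1 to compound 2 (within the scatter), a step of similar size, well within the scatter, is expected here: a number 3.2 percentage points higher from compound 3 to compound 4 (within the scatter). Compound 4 is therefore estimated at 78%, with a likely range from 68% to 88%.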

Compound 4, a percentage reported as inhibition, in the whole organism at one dose (the size of the read-out at that dose, not a potency): 73.9%
For compound 4 the middle estimate is 4.1 percentage points above the measured one; the measured number falls inside the stated range.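

In this assay, methyl in place of the amide hydrogen gave a number 0.9 percentage points lower from compound 3 to compound 4 (within the scatter). The change therefore behaves alike on these two cores, with neither step standing out from the noise of the measurement: the same change on two cores in this assay, a number 4.2 percentage points higher (within the scatter) from compound 1 to compound 2 and a number 0.9 percentage points lower (within the scatter) from compound 3 to compound 4, 5.1 percentage points apart, within the scatter of two such steps. This does not show that methyl is without effect on every core, and two cores are too few to set a rule for the series.

The compounds shown leave open whether a larger group on that nitrogen, such as a benzyl group or a longer chain ending in an amine, would give a step beyond the scatter. With only one dose shown, how the inhibition of swelling changes with dose also stays open.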